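The compounds below may be only part of what the source reports. "The series", "measured", "known", "first", "only" and "open" are said of these compounds alone.

Compound 3 (`CC(C)c1c(Cc2c(F)cccc2Cl)nc(SCC(=O)c2ccccc2)[nH]c1=O`) is the starting point for this step. In an ADME assay on MT4 cells (Homo sapiens) for cytotoxicity, read by MTT assay (on this read-out lower numbers stand for higher toxicity in this test and higher numbers for lower toxicity in this test), compound 3 gives > 12000 nM, which is a limit and not a number. Compound 1 (`COc1ccc(C(=O)CSc2nc(Cc3c(F)cccc3Cl)cc(=O)[nH]2)cc1`) gives > 12000 nM in this assay, also a limit. Compound 2 (`COc1ccc(C(=O)CSc2nc(Cc3c(F)cccc3Cl)c(C)c(=O)[nH]2)cc1`) gives > 12000 nM, again a limit. Compound 3 therefore has no rank of its own within the series, and the whole picture so far is the limit of > 12000 nM in this assay, at which 3 of the 3 values shown sit.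

Compound 4 (`COc1ccc(C(=O)CSc2nc(Cc3c(F)cccc3Cl)c(C(C)C)c(=O)[nH]2)cc1`) differs from compound 3 by methoxy in place of hydrogen on an aromatic carbon, para to a large group, so that phenyl becomes 4-methoxyphenyl: methoxy in place of hydrogen on an aromatic carbon. Within the data shown here, no measured step isolates this change. Among the measured compounds shown here, the only step available is a step that the two limits leave unreadable from compound 1 to compound 2, which is a different change, methyl in place of hydrogen on an aromatic carbon, and its size cannot be read. The expectation rests instead on compound 2, which already carries the 4-methoxyphenyl group and reads > 12000 nM, a limit. No step beyond the scatter is expected in this assay, in either direction, and compound 4 may well be reported only as a limit too. The estimate amounts to a step that the limit leaves unreadable from compound 3 to compound 4. For compound 4 the estimated value is 15000 nM, with an expected range from 8000 nM to 40000 nM.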

Compound 4, half-maximal cytotoxic concentration: > 11000 nM
Compound 4: only a limit was reported (the forecaster's own chance of this, stated with the estimate: 80%); the middle value lies beyond the limit too.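

In this assay compound 4 gives > 11000 nM, which is a limit. The steps to compound 4 from compound 1, compound 2 and compound 3 cannot be read, as all four values are limits. The compounds shown leave open whether methoxy or isopropyl in these places shifts the half-maximal cytotoxic concentration at all.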